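The source may report more compounds than this note shows. Statements on the series, on what has been measured and on what is new or still open speak of the compounds shown alone.

Compound 2 `N#C/C=C/c1ccc(-c2cnc(C(=O)CCCCCCc3ccccc3)o2)nc1` gives 2.7 nM in an assay for inhibition of Fatty-acid amide hydrolase 1 (Rattus norvegicus), using a Dixon plot, with a stated time of 6 h (on this read-out higher numbers stand for weaker inhibition and lower numbers for stronger inhibition), the lowest of the two numbers recorded, the nearest being compound 1 `O=C(CCCCCCc1ccccc1)c1ncc(-c2ccc(CCl)cn2)o1`, which gives 24.6 nM. For the measured compounds named here, that gap is the one measured step, a 9.1-fold lower number from compound 1 to compound 2 (0.96 log units; beyond the scatter), and it concerns the exchange of chloromethyl for 2-cyanoethenyl on an aromatic carbon. Compound 3 `CCOS(=O)(=O)/C=C/c1ccc(-c2cnc(C(=O)CCCCCCc3ccccc3)o2)nc1` differs from compound 2 by ethoxysulfonyl in place of cyano on a double-bonded chain carbon bound to a double-bonded chain carbon. Going by the values given here, no measured step concerns an exchange of the group on the double-bonded chain carbon, so the single step recorded gives no direct guide to the size or direction of this one. The numbers of compound 1 and compound 2 do show that changes in this part of the structure can move this assay well beyond the scatter, so the step is expected to be of uncertain direction with a wide spread. Compound 3 is therefore expected to show a 3.0-fold higher number from compound 2 to compound 3 (0.47 log units; beyond the scatter), with an estimate of 8 nM and a range from 1.5 nM to 45 nM.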

Compound 3, inhibition constant: 0.2 nM
For compound 3 the middle estimate is 40-fold (1.60 log units) above the measured one; measured number outside the range, below it.
By their numbers in this assay, from the lowest: compound 3; then compound 2; then compound 1.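

In this assay the group on the double-bonded chain carbon proves to matter in its own right: ethoxysulfonyl in place of cyano gives a 14-fold lower number from compound 2 to compound 3 (1.13 log units; beyond the scatter) and so shows that this position can still be moved once the 2-cyanoethenyl chain is in place. Set against the chloromethyl starting point, the 2-(ethoxysulfonyl)ethenyl chain gives a 120-fold lower number from compound 1 to compound 3 (2.09 log units; beyond the scatter) and carries the number further down than the earlier step alone did. Nothing measured here accounts for the effect of the ethoxysulfonyl group.

The compounds shown leave open whether the ethoxy part is needed, which a sulfonamide or a carboxylic acid on the same double-bonded chain carbon would test. On these data alone, whether the step keeps its size with a shorter chain on the carbonyl also remains open.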